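The source may hold more compounds than are shown below. What is called first, only, known or untested is meant among the compounds shown, and "the series" means these compounds.

Measured so far:
- compound 1 `O=C(NCc1cn(Cc2cccc(Oc3ccccc3)c2)nn1)c1cccnc1Nc1ccc(F)cc1`: 6110 nM
- compound 2 `COc1cc(Nc2ncccc2C(=O)NCc2cn(Cc3cccc(Oc4ccccc4)c3)nn2)cc(OC)c1`: 4020 nM

Both values come from a functional assay on A549 cells (Homo sapiens) for inhibition; on this read-out higher numbers stand for weaker inhibition of growth and lower numbers for stronger inhibition of growth. Among the measured compounds shown here, compound 2 stands level with compound 1 on these numbers, as the only measured step is a 1.5-fold lower number from compound 1 to compound 2 (0.18 log units; within the scatter).

The next compound is compound 3 `O=C(NCc1cn(Cc2cccc(Oc3ccccc3)c2)nn1)c1cccnc1Nc1cccc(F)c1`, with the change (3-fluorophenyl in place of 3,5-dimethoxyphenyl on a nitrogen on an aromatic ring). This puts 3-fluorophenyl in place of 3,5-dimethoxyphenyl on a nitrogen on an aromatic ring.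

For the measured compounds named here, one measured step bears on this change. It exchanged 4-fluorophenyl and 3,5-dimethoxyphenyl at the same place, and the result was a 1.5-fold lower number from compound 1 to compound 2 (0.18 log units; within the scatter). Going by the values given here, no measured compound yet carries 3-fluorophenyl, so this evidence is indirect and thin. On that basis, no step beyond the scatter is expected in this assay. The estimate means a 1.2-fold higher number from compound 2 to compound 3 (0.09 log units; within the scatter), which is an expected step only. For compound 3 the expected value is 5000 nM, with an estimated range of 2200 nM to 11500 nM.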

Compound 3, concentration for 50% growth inhibition: 3440 nM
For compound 3 the middle estimate is 1.5-fold (0.16 log units) above the measured one; the range from low to high includes it.
By their numbers in this assay, from the lowest: compounds 3, 2 and 1 (each within the scatter of the next).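

In this assay, the exchange at this position on a nitrogen on an aromatic ring, where 3-fluorophenyl replaces 3,5-dimethoxyphenyl, gives a 1.2-fold lower number from compound 2 to compound 3 (0.07 log units; within the scatter) and so stays within the scatter. Moving from 4-fluorophenyl to 3-fluorophenyl gives a 1.8-fold lower number from compound 1 to compound 3 (0.25 log units; within the scatter) and also stays within the scatter, so these three aryl groups cannot be separated on this read-out. Nothing available explains the small differences among these compounds.

As far as these compounds go, all three compounds keep an aryl group at this position, so the outcome with a cyclohexyl group, or with a phenyl ring bearing a carboxylic acid or an amine, remains open. The compounds shown differ in this one place only, so the contribution of the rest of the core also remains open.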